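Clearance of compound 3 after shortening a side chain

The source may hold more compounds than are shown below. What is called first, only, known or untested is meant among the compounds shown, and "the series" means these compounds.

Values in an ADME assay on the whole organism for pharmacokinetics, with Rattus norvegicus as the target, at a dose of 2 mg/kg by the intravenous route (on this read-out lower numbers stand for slow clearance and higher numbers for fast clearance), follow
compound 1 `O=c1[nH]c2ncc(-c3ccc(-c4nc[nH]n4)cc3)nc2n1CCC1CCOCC1` gives 32 mL/min/kg
compound 2 `CO[C@H]1CC[C@@H](CN2CC(=O)Nc3ncc(-c4ccc(C(C)(C)O)nc4)nc32)CC1` gives "not determined" (no result reported)

Compound 2 has no single number to stand on, since its entry reads "not determined" (no result reported) and so it cannot be ranked against compound 1. The only measured clearance is that of compound 1 at 32 mL/min/kg, and that compound has a different core and a different side chain. Compound 3 `CO[C@H]1CC[C@H](N2CC(=O)Nc3ncc(-c4ccc(C(C)(C)O)nc4)nc32)CC1` has not yet been measured. The change 4-methoxycyclohexyl in place of (4-methoxycyclohexyl)methyl on a nitrogen on an aromatic ring in a ring puts 4-methoxycyclohexyl in place of (4-methoxycyclohexyl)methyl on a nitrogen on an aromatic ring in a ring. Within the data shown here, with no number for compound 2, no measured step guides the expectation in this assay, so a step no larger than the usual scatter is expected, in neither direction. For compound 3 the estimated clearance is 14 mL/min/kg within an expected range of 6 mL/min/kg to 32 mL/min/kg in this assay.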

Compound 3, clearance: 1.7 mL/min/kg
Compound 3: the middle estimate sits 8.2-fold (0.92 log units) above what was measured, and the stated range ends above it.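

In this assay, among these compounds, compound 3 gives 1.7 mL/min/kg but compound 2 has no number to set beside it, so no step between the two can be read. The compounds shown leave open how 4-methoxycyclohexyl and (4-methoxycyclohexyl)methyl compare on clearance. Nothing shown bears on what lies behind this result.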